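The compounds below may be only part of what the source reports. "The series", "measured", "known", "first", "only" and "open" are said of these compounds alone.

Compound 2 `O=C(C1CCCO1)N1CCc2nc(C#Cc3ccccc3)sc2C1` carries an oxolan-2-yl group on the carbonyl carbon of its amide. Among the measured compounds shown here, in an assay on HEK293 cells for positive allosteric modulation of metabotropic glutamate receptor 5 (Homo sapiens), read by FLIPR, with a stated time of 1 h (on this read-out higher numbers stand for an effect only at larger amounts of compound and lower numbers for an effect already at smaller amounts), compound 2 gives 790 nM, which is the only actual number among the two measured compounds. Its neighbour compound 1 `CCC(=O)N1CCc2nc(C#Cc3ccccc3)sc2C1` carries an ethyl group in the same place. In this assay compound 1 reaches only a limit of the assay, > 10000 nM. For the measured compounds named here, the step of an at least 12-fold lower number from compound 1 to compound 2 (1.10 log units; beyond the scatter) is the single measured comparison here, and since one end of it sits at the limit of > 10000 nM in this assay, at which 1 of the 2 values shown sits, its true size is not known beyond being large. Compound 3 `O=C(c1cccc(Cl)c1)N1CCc2nc(C#Cc3ccccc3)sc2C1` differs from compound 2 by 3-chlorophenyl in place of oxolan-2-yl on a carbonyl carbon. Going by the values given here, no measured step turns a five-membered non-aromatic ring into an aromatic ring, so the measured comparison shows only that the group on this carbonyl carbon can shift the number by a large amount in either direction. The expected step of a 2.0-fold lower number from compound 2 to compound 3 (0.30 log units; within the scatter) is therefore set close to no change, with wide uncertainty. In this assay compound 3 is expected to give 400 nM, within a range from 60 nM to 3000 nM.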

Compound 3, half-maximal effective concentration: 8.7 nM
Compound 3: the middle estimate sits 46-fold (1.66 log units) above what was measured; measured number outside the range, below it.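

On the carbonyl carbon whose other neighbour is the amide-type nitrogen in a ring, the group can do more than the earlier comparison showed: in this assay, swapping the five-membered non-aromatic oxolan-2-yl for the six-membered aromatic 3-chlorophenyl gives a 91-fold lower number from compound 2 to compound 3 (1.96 log units; beyond the scatter), so a ring at this place does not merely restore some effect but can take the number much lower. Against the ethyl group, the same place gives an at least 1100-fold lower number from compound 1 to compound 3 (3.06 log units; beyond the scatter), which means that across the three compounds this one point of change spans a very wide range while the shared core stays the same. The true size of that second step is not known, because compound 1 stands at a limit rather than at a number: the limit of > 10000 nM in this assay, at which 1 of the 3 values shown sits.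

As far as these compounds go, whether the lower number of compound 3 belongs to the aromatic ring itself or to its chlorine stays open, and a plain phenyl group on this carbonyl carbon would separate the two. From the compounds shown here alone, how a pyridine ring, or a phenyl ring carrying an amine or a carboxylic acid, would read at this place also remains unknown.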